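The compounds below may be only part of what the source reports. "The series", "measured", "known", "first", "only" and "open" are said of these compounds alone.

Measured in a toxicity assay on CHO cells (Cricetulus griseus) for cytotoxicity, read by WST assay, with a stated time of 24 h; on this read-out lower numbers stand for stronger inhibition and higher numbers for weaker inhibition:
- compound 1 `CC(C)=CCC/C(C)=C\CCC(C)=CCNCCCN`: 32100 nM
- compound 2 `CC(C)=CCC/C(C)=C\CCC(C)=CCNCCCCN`: 18100 nM
- compound 3 `CC(C)=CCC/C(C)=C\CCC(C)=CCNCCCN1CCCC1`: 85300 nM

Of these three, compound 3 has the highest number, 85300 nM, which makes it the weakest inhibitor here. The next compound, compound 4 `CC(C)=CCC/C(C)=C\CCC(C)=CCNCCCNCCCN`, differs from it in one place: (3-aminopropyl)amino in place of pyrrolidin-1-yl on a saturated chain carbon, three bonds along the chain from an amine nitrogen. The ring is replaced by an open chain, (3-aminopropyl)amino.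

Among the compounds with values here, no measured compound carries this group, so the evidence is indirect. The closest guides are the steps that put pyrrolidin-1-yl in place of an open group: a 2.7-fold higher number from compound 1 to compound 3 (0.42 log units; beyond the scatter), and a 4.7-fold higher number from compound 2 to compound 3 (0.67 log units; beyond the scatter). Read in reverse, both suggest that losing pyrrolidin-1-yl should lower the number. The remaining step, a 1.8-fold lower number from compound 1 to compound 2 (0.25 log units; within the scatter), gives no clear guide.

The expected step in this assay is therefore modest and towards a lower number, a 3.4-fold lower number from compound 3 to compound 4 (0.53 log units; beyond the scatter). For compound 4 the estimated value is 25000 nM, with an expected range of 8000 nM to 70000 nM.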

Compound 4, half-maximal inhibitory concentration: 30200 nM
Compound 4: middle estimate off by 1.2-fold (0.08 log units), on the low side, and the stated range covers the measured number.
By their numbers in this assay, from the lowest: compounds 2, 4 and 1 (each within the scatter of the next); then compound 3.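

In this assay the open chain gives a 2.8-fold lower number from compound 3 to compound 4 (0.45 log units; beyond the scatter), although pyrrolidin-1-yl and (3-aminopropyl)amino both have 5 heavy atoms, so the higher number of compound 3 goes with the ring form of this end group and not with its size. Lengthening the open chain moves nothing that this read-out can resolve: a 1.7-fold higher number from compound 2 to compound 4 (0.22 log units; within the scatter) and a 1.1-fold lower number from compound 1 to compound 4 (0.03 log units; within the scatter) both lie within the scatter, which leaves compound 3 as the only one set apart from the others. Nothing measured here explains why the ring and the open chains differ.

Only one ring is shown at this place, so a piperidin-1-yl or morpholin-4-yl group would be needed to tell whether other rings behave like pyrrolidin-1-yl. A dimethylamino group would separate the effect of closing the ring from that of simply capping the nitrogen with carbon groups.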